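Adding a second ester to compound 3

The source may hold more compounds than are shown below. What is called first, only, known or untested is meant among the compounds shown, and "the series" means these compounds.

Measured in an ADME assay on HepG2 2.2.15 cells (Homo sapiens) for cytotoxicity, read by MTT assay; on this read-out higher numbers stand for lower toxicity in this test and lower numbers for higher toxicity in this test:
- compound 1 `C=C1CC[C@@H]2[C@](C)(COC(=O)c3ccccc3C(=O)O)[C@H](OC(=O)c3ccccc3C(=O)O)CC[C@@]2(C)[C@@H]1/C=C/C1=CCOC1=O`: > 1620000 nM
- compound 2 `C=C1CC[C@@H]2[C@](C)(COC(=O)c3cccs3)[C@H](O)CC[C@@]2(C)[C@@H]1C/C=C1\C=COC1=O`: 2470000 nM
- compound 3 `C=C1CC[C@@H]2[C@](C)(COC(=O)c3ccccc3C(=O)O)[C@H](O)CC[C@@]2(C)[C@@H]1C/C=C1\C=COC1=O`: 450000 nM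

Compound 1 gives > 1620000 nM, which is a limit of the assay and not a number. Of the two true numbers, compound 3 holds the lower one, 450000 nM, and compound 2 gives 2470000 nM. That gap is a 5.5-fold lower number from compound 2 to compound 3 (0.74 log units; beyond the scatter).

Compound 4 `C=C1CC[C@@H]2[C@](C)(COC(=O)c3ccccc3C(=O)O)[C@H](OC(=O)c3ccccc3C(=O)O)CC[C@@]2(C)[C@@H]1C/C=C1\C=COC1=O` comes from compound 3 by one change (2-carboxyphenyl)carbonyl in place of hydrogen on an oxygen on a saturated carbon: (2-carboxyphenyl)carbonyl takes the place of hydrogen on an oxygen on a saturated carbon. Within the data shown here, no measured step makes exactly this change. The nearest, a 5.5-fold lower number from compound 2 to compound 3 (0.74 log units; beyond the scatter), swaps a group at another ester and points downward. Compound 1 points the other way, since it already carries (2-carboxyphenyl)carbonyl on this oxygen, though it differs from compound 4 elsewhere, and it ends at the limit of > 1620000 nM in this assay, at which 1 of the 3 values shown sits. The second clue is the closer match, so a modest rise in this assay is expected, with the expected size being a 2.0-fold higher number from compound 3 to compound 4 (0.30 log units; within the scatter). The estimate for compound 4 is 900000 nM, with an expected range of 300000 nM to 1800000 nM.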

Compound 4, half-maximal cytotoxic concentration: > 2040000 nM
Compound 4: only a limit was reported; the forecaster's own chance of this, stated with the estimate: 40%; middle value at least 2.2-fold (0.35 log units) from the limit.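

In this assay, among these compounds, going from hydroxy to ((2-carboxyphenyl)carbonyl)oxy on the saturated carbon gives an at least 4.5-fold higher number from compound 3 to compound 4 (0.65 log units; beyond the scatter), the first direct reading of a change at this oxygen, and the higher number stands for lower toxicity in this test. Going by these compounds, the reading for compound 4 is a limit of the assay and not a number, so the full size of this step stays unknown: the limit of > 2040000 nM in this assay, at which 1 of the 4 values shown sits. Compound 1 and compound 4 both give limits, and the step between them cannot be read.

The compounds shown leave open whether a plain benzoyl or an acetyl on this oxygen would give a similar rise, or whether the rise needs the carboxylic acid of the entering group. They also leave open whether the same change on compound 2, with its thiophen-2-yl ester, would move the number the same way.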